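The compounds below may be only part of what the source reports. "The series", "measured", "known", "first", "only" and "open" are said of these compounds alone.

In a functional assay on HL-60 cells (Homo sapiens) for cytotoxicity, read by WST assay, with a stated time of 48 h (on this read-out lower numbers stand for an effect already at smaller amounts and higher numbers for an effect only at larger amounts of compound), compound 1 `Oc1ccccc1C[C@H]1COC[C@@H]1Cc1ccc(Cl)c(Cl)c1` gives 34000 nM while compound 2 `Cc1ccccc1C[C@H]1COC[C@@H]1Cc1ccc(Cl)c(Cl)c1` gives 21000 nM and compound 3 `Fc1ccccc1C[C@H]1COC[C@@H]1Cc1ccc(Cl)c(Cl)c1` gives 51000 nM on the same core. The move a 1.5-fold higher number from compound 1 to compound 3 (0.18 log units; within the scatter) stays within the scatter, whereas a 2.4-fold higher number from compound 2 to compound 3 (0.39 log units; beyond the scatter) is modest. Compound 3 thus sits at the upper end of this small set, alongside compound 1. Compound 4 `Oc1cccc(C[C@H]2COC[C@@H]2Cc2ccc(Cl)c(Cl)c2)c1` changes one place: 3-hydroxyphenyl in place of 2-fluorophenyl on a saturated chain carbon bound to a saturated ring carbon with 3-hydroxyphenyl in place of 2-fluorophenyl on a saturated chain carbon bound to a saturated ring carbon. Among the compounds with values here, the best guide is the hydroxy-bearing compound 1, since the swap a 1.5-fold higher number from compound 1 to compound 3 (0.18 log units; within the scatter) is small, and no measured step here is large. The expected change, a 1.5-fold lower number from compound 3 to compound 4 (0.16 log units; within the scatter), is therefore estimated to stay within the scatter. Compound 4 is expected near 35000 nM with an estimated range from 16000 nM to 75000 nM in this assay.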

Compound 4, half-maximal effective concentration: 31000 nM
The estimate for compound 4 lay 1.1-fold (0.05 log units) above the measured number; the range from low to high includes it.
By their numbers in this assay, from the lowest: compounds 2, 4, 1 and 3 (each within the scatter of the next, the first and the last beyond it).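

In this assay the step of a 1.1-fold lower number from compound 1 to compound 4 (0.04 log units; within the scatter) with 3-hydroxyphenyl in place of 2-hydroxyphenyl shows that these two hydroxyphenyl groups cannot be told apart on the shared core. Within the data shown here, likewise a 1.6-fold lower number from compound 3 to compound 4 (0.22 log units; within the scatter) and a 1.5-fold higher number from compound 2 to compound 4 (0.17 log units; within the scatter) stay within the scatter, so compound 4 separates from none of the earlier compounds, although compound 2 and compound 3 do separate from each other. Nothing measured here offers an explanation for this result. Going by these compounds, whether an amine or a carboxylic acid on the phenyl ring, or a longer chain at this saturated chain carbon, would shift the number beyond the scatter remains open.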